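A few compounds are considered here, and "the series" means these few. Any claim that something is new, unique, unknown or untested is made for them only; others in the source may bear on it.

Within the data shown here, in a functional assay on G-361 cells (Homo sapiens) for cytotoxicity, read by MTT assay, with a stated time of 3 days (a lower number here means a stronger inhibitor, a higher number a weaker inhibitor), compound 1 `N#Cc1c(NN)nc(SCc2nc3ccccc3[nH]2)nc1-c1ccccc1` gives 14.7 nM and compound 2 `N#Cc1c(NNC(N)=S)nc(SCc2nc3ccccc3[nH]2)nc1-c1ccccc1` gives 3.96 nM as the lower of the two numbers so far. Compound 3 `N#Cc1c(NC(N)=S)nc(SCc2nc3ccccc3[nH]2)nc1-c1ccccc1` has not yet been measured, and its structure departs from compound 2 by a group of 3 heavy atoms (1 carbon, 1 nitrogen, 1 sulfur; no ring) in place of a group of 4 heavy atoms (1 carbon, 2 nitrogen, 1 sulfur; no ring), on a nitrogen on an aromatic ring on the shared core.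

Among the measured compounds shown here, only one measured step bears on this change. It is a 3.7-fold lower number from compound 1 to compound 2 (0.57 log units; beyond the scatter) and is a modest step, beyond the scatter, on placing a group of 3 heavy atoms on an amine nitrogen in place of a hydrogen atom. The group entering compound 3 fits the same description but stands on a nitrogen on an aromatic ring, so that step is only a loose guide. For the measured compounds named here, no measured pair shows what happens when the group of 4 heavy atoms leaves.

Going by the values given here, a modest rise is therefore expected, no larger in size than the one measured step. The estimated change is a 2.3-fold higher number from compound 2 to compound 3 (0.36 log units; beyond the scatter) in this assay at its middle, with a wide margin. Compound 3 is expected at 9 nM with an estimated range from 2.5 nM to 32 nM once it is tested.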

Compound 3, half-maximal inhibitory concentration: 5.81 nM
Estimate against measurement, compound 3: 1.5-fold (0.19 log units) above; measured number inside the range.
By their numbers in this assay, from the lowest: compounds 2 and 3 (each within the scatter of the next); then compound 1.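

In this assay the step of a 1.5-fold higher number from compound 2 to compound 3 (0.17 log units; within the scatter) shows that, on a nitrogen on an aromatic ring, the group of 3 heavy atoms and the group of 4 heavy atoms cannot be told apart by this read-out. The step of a 2.5-fold lower number from compound 1 to compound 3 (0.40 log units; beyond the scatter) shows that the group of 3 heavy atoms in place of one nitrogen atom also separates from compound 1 beyond the scatter, so two different changes to compound 1 now end at numbers within the scatter of each other, compound 2 and compound 3. Nothing available here accounts for this result or for the closeness of compound 2 and compound 3.

The compounds shown leave open whether the sulfur of these groups matters, since a carbonyl in its place, giving a urea, does not appear among them. They also leave open whether a methyl or a longer chain on the same nitrogen, or a plain amine or an acetyl group there, would keep the number near those of compound 2 and compound 3.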